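The compounds below may be only part of what the source reports. "The series", "measured", "known", "first", "only" and "open" are said of these compounds alone.

Measured so far in a functional assay on MCF7 cells (Homo sapiens) for cytotoxicity, read by CellTiter-Glo, with a stated time of 5 days; a higher number here means a weaker inhibitor, a lower number a stronger inhibitor
- compound 1 `CC/C(=C(/c1ccc(/C=C/C(=O)O)cc1)c1ccc2[nH]ncc2c1)c1ccccc1Cl` gives 2 nM
- compound 2 `CC/C(=C(/c1ccc(/C=C/C(=O)O)cc1)c1ccc2[nH]ncc2c1)c1cccc(Cl)c1` gives 12 nM
- compound 3 `CC/C(=C(/c1ccc(/C=C/C(=O)O)cc1)c1ccc2[nH]ncc2c1)c1ccc(C#N)cc1C` gives 5 nM

Compound 3 at 5 nM holds the middle place of the three numbers, with compound 1 lower and compound 2 higher. The next change lies on a double-bonded chain carbon bound to a double-bonded chain carbon and a saturated chain carbon. There, compound 4 `CC/C(=C(/c1ccc(/C=C/C(=O)O)cc1)c1ccc2[nH]ncc2c1)c1cccnc1C` carries 2-methylpyridin-3-yl in place of 4-cyano-2-methylphenyl (2-methylpyridin-3-yl in place of 4-cyano-2-methylphenyl on a double-bonded chain carbon bound to a double-bonded chain carbon and a saturated chain carbon).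

Three measured steps at this same place bear on it: a 6.0-fold higher number from compound 1 to compound 2 (0.78 log units; beyond the scatter) and a 2.5-fold higher number from compound 1 to compound 3 (0.40 log units; beyond the scatter) and a 2.4-fold lower number from compound 2 to compound 3 (0.38 log units; beyond the scatter) are all modest. For the measured compounds named here, no measured compound carries a ring with a hetero atom here, so the direction is uncertain. A modest move toward a higher number is expected in this assay, since only compound 1 at 2 nM lies lower.

The estimated step is a 2.4-fold higher number from compound 3 to compound 4 (0.38 log units; beyond the scatter) on this reasoning. Compound 4 is estimated at 12 nM with an expected range from 4 nM to 40 nM in this series.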

Compound 4, half-maximal inhibitory concentration: 200 nM
For compound 4 the middle estimate is 17-fold (1.22 log units) below the measured one; measured number above the stated range.
By their numbers in this assay, from the lowest: compound 1; then compound 3; then compound 2; then compound 4.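

In this assay, for the compounds shown here, the place on a double-bonded chain carbon bound to a double-bonded chain carbon and a saturated chain carbon separates the groups far more sharply than the earlier compounds showed: 2-methylpyridin-3-yl brings a 40-fold higher number from compound 3 to compound 4 (1.60 log units; beyond the scatter) and a 17-fold higher number from compound 2 to compound 4 (1.22 log units; beyond the scatter) and also a 100-fold higher number from compound 1 to compound 4 (2.00 log units; beyond the scatter) as large steps. Compounds 1, 2 and 3, each with an aromatic ring of carbon only here, stay within modest steps of one another, so compound 4 alone sets the wide spread. Nothing available here explains the size of these steps.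

Compound 4 differs from compound 3 in both the ring nitrogen and the nitrile, and these two changes cannot be separated on the present compounds. A 2-methylphenyl group, or a pyridine ring bearing chlorine, would test whether the ring nitrogen alone goes with the higher number.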